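Varying the sulfur-linked side chain of a shared core

This account rests on a few compounds, and the source may have more. Where it says the series, first, only, none or still open, it means among the compounds named here.

Compound 1, `CCC(O)CSc1nc(NCc2ccc(-c3ccccn3)cc2)c2[nH]nc(C(C)C)c2n1`: 273 nM in a functional assay on HT cells (Homo sapiens) for antiproliferative activity, read by fluorescence, with a stated time of 72 h; on this read-out lower numbers stand for stronger inhibition of growth and higher numbers for weaker inhibition of growth
Compound 2, `CC(C)c1n[nH]c2c(NCc3ccc(-c4ccccn4)cc3)nc(SCC3CNC(=O)O3)nc12`: 80 nM in this assay

Among the two measured compounds, compound 1 has the highest number in this assay; its nearest neighbour is compound 2, reached by a 3.4-fold lower number from compound 1 to compound 2 (0.53 log units; beyond the scatter). Compound 3, `CC(=O)NCCSc1nc(NCc2ccc(-c3ccccn3)cc2)c2[nH]nc(C(C)C)c2n1`, is not yet measured. It differs from compound 1 by acetamidomethyl in place of 1-hydroxypropyl on a saturated chain carbon bound to a sulfur. Among the measured compounds shown here, only one measured step bears on this change: the step from compound 1 to compound 2 also replaces the 1-hydroxypropyl group on the saturated chain carbon bound to sulfur, there with a ring, and gave a 3.4-fold lower number from compound 1 to compound 2 (0.53 log units; beyond the scatter). Acetamidomethyl is an open chain rather than a ring, so that step is only a loose guide; the replacement keeps one hydrogen-bond donor and one acceptor. Compound 3 is therefore expected to lie close to compound 1 or modestly lower, as a 1.4-fold lower number from compound 1 to compound 3 (0.14 log units; within the scatter). The estimate for compound 3 is 200 nM, within the range 70 nM to 600 nM.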

Compound 3, concentration for 50% growth inhibition: 71 nM
Beside the measured number, compound 3's estimate is 2.8-fold (0.45 log units) above it, and the stated range covers the measured number.
By their numbers in this assay, from the lowest: compounds 3 and 2 (each within the scatter of the next); then compound 1.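

In this assay, the open-chain acetamidomethyl group also gives a step beyond the scatter, a 3.8-fold lower number from compound 1 to compound 3 (0.58 log units; beyond the scatter), so among these compounds a ring in the side chain is not needed for a lower number than that of compound 1. The two replacements cannot be separated, a 1.1-fold lower number from compound 2 to compound 3 (0.05 log units; within the scatter), and since 1-hydroxypropyl and acetamidomethyl have the same counts of hydrogen-bond donors and acceptors, those counts do not track the change seen here. Nothing among the data gives a reason for the step.

The compounds shown leave open how a carboxylic acid or a simple amine would compare on this saturated chain carbon bound to a sulfur. They also leave open whether a longer chain ending in the same acetamido group would stay close to compound 3 at 71 nM.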